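Chloro to bromo on a nearly inactive amide

The compounds below may be only part of what the source reports. "The series", "measured", "known", "first", "only" and "open" are said of these compounds alone.

Compound 1 `Cc1oc2ncnc(Nc3cccc(Cl)c3)c2c1C(=O)NCCO`: > 1000000 nM
Compound 2 `Cc1oc2ncnc(Nc3cccc(Cl)c3)c2c1C(=O)NC(C)C`: 191000 nM

In a functional assay on MCF7 cells (Homo sapiens) for cytotoxicity, read by MTT assay, with a stated time of 72 h (on this read-out higher numbers stand for weaker inhibition and lower numbers for stronger inhibition), compound 1 gives > 1000000 nM, which is a limit and not a number. Compound 1 stands at the limit of > 1000000 nM in this assay, at which 1 of the 2 values shown sits.

Compound 3 `Cc1oc2ncnc(Nc3cccc(Br)c3)c2c1C(=O)NCCO` keeps the 2-hydroxyethyl group of compound 1 and changes only the halogen: bromo in place of chloro on an aromatic carbon. This puts bromo in place of chloro on an aromatic carbon, meta to a large group.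

Going by the values given here, the only measured step is an at least 5.2-fold lower number from compound 1 to compound 2 (0.71 log units; beyond the scatter), with isopropyl in place of 2-hydroxyethyl on an amide-type nitrogen. That step lies beyond the scatter, but it sits at a different place, so it gives no size for a halogen swap. Compound 3 retains the group that was given up in an at least 5.2-fold lower number from compound 1 to compound 2 (0.71 log units; beyond the scatter), so no comparable gain is expected here.

The expected change is a number no higher from compound 1 to compound 3 (the limit leaves the size open), which means no step beyond the scatter is expected in this assay. Compound 3 is estimated at 1000000 nM, with an expected range of 300000 nM to 3000000 nM.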

Compound 3, half-maximal inhibitory concentration: 22000 nM
For compound 3 the middle estimate is 45-fold (1.66 log units) above the measured one; the measured number lies below the stated range.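

In this assay, going by these compounds alone, exchanging one halogen for another on the aromatic ring gives an at least 45-fold lower number from compound 1 to compound 3 (1.65 log units; beyond the scatter), so this place on the ring has a strong bearing on the read-out even though only a single atom changes. Within the data shown here, until now the only measured change was at the amide, but compound 3 keeps the 2-hydroxyethyl group and still gives 22000 nM, which shows that this group does not by itself hold a compound at the top of the scale. The true size of the step stays open because the value of compound 1 is a limit and not a number: the limit of > 1000000 nM in this assay, at which 1 of the 3 values shown sits.

The compounds shown leave open whether the trend runs on to iodo, or whether a non-halogen group such as methyl or methoxy at the same place would serve as well as bromo. They also leave open whether 3-bromophenyl would bring a similar gain when paired with the isopropyl amide of compound 2, or with an amide carrying a longer chain.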